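Compound 2 to compound 3: chloro gives way to fluoro

The source may report more compounds than this note shows. Statements on the series, on what has been measured and on what is new or still open speak of the compounds shown alone.

Compound 1 `Cc1cc(S(N)(=O)=O)ccc1NC(=O)COc1ccc(Cl)cc1NC(=O)c1ccccc1`: 207000 nM
Compound 2 `Cc1cc(S(N)(=O)=O)ccc1NC(=O)COc1ccc(Cl)cc1NC(=O)c1cccc(Cl)c1`: 59700 nM

In a functional assay on C8166 cells (Homo sapiens) for cytotoxicity, read by MTT assay (a higher number here means that more compound is tolerated, a lower number that less compound is tolerated), compound 2 holds the lower of the two numbers, at 59700 nM, against compound 1 at 207000 nM. Compound 3 `Cc1cc(S(N)(=O)=O)ccc1NC(=O)COc1ccc(Cl)cc1NC(=O)c1cccc(F)c1` has not been measured. It carries fluoro in place of chloro on an aromatic carbon, turning the 3-chlorophenyl into a 3-fluorophenyl: fluoro in place of chloro on an aromatic carbon. Within the data shown here, only one measured step bears on this, a 3.5-fold lower number from compound 1 to compound 2 (0.54 log units; beyond the scatter), which came with chloro in place of hydrogen on an aromatic carbon. Among the measured compounds shown here, no fluoro compound has a measured value, so the guide is thin. A partial return towards compound 1 is expected, smaller than that step and perhaps not clear of the scatter. The expected step is a 1.8-fold higher number from compound 2 to compound 3 (0.27 log units; within the scatter). Compound 3 is estimated at 110000 nM, with an expected range of 50000 nM to 230000 nM.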

Compound 3, half-maximal cytotoxic concentration: 243000 nM
Estimate against measurement, compound 3: 2.2-fold (0.34 log units) below; the measured number lies above the stated range.
By their numbers in this assay, from the lowest: compound 2; then compounds 1 and 3 (each within the scatter of the next).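

In this assay, the change from the 3-chlorophenyl to the 3-fluorophenyl gives a 4.1-fold higher number from compound 2 to compound 3 (0.61 log units; beyond the scatter), so the earlier drop on adding chloro at this aromatic carbon does not carry over to fluoro. Set against hydrogen at the same carbon, fluoro gives a 1.2-fold higher number from compound 1 to compound 3 (0.07 log units; within the scatter), which leaves the two indistinguishable here and makes chloro the only one of the three substituents that stands apart, with the lower number. Nothing shown gives a reason for this difference between chloro and fluoro.

Going by these compounds, whether bromo or methoxy on this aromatic carbon would side with chloro or with fluoro remains open. On these data alone, it also remains open whether the gap between chloro and fluoro would hold on another carbon of the same ring.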